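Dropping the Methylene Link of a Benzylic Sulfonamide

The source may hold more compounds than are shown below. What is called first, only, known or untested is meant among the compounds shown, and "the series" means these compounds.

Three ureas share one aryl half and differ in the other. Compound 1 `O=C(Nc1ccc(Cl)c(C(F)(F)F)c1)Nc1cccc2c(O)cccc12` carries a hydroxy-substituted bicyclic aromatic ring; compound 2 `CS(=O)(=O)Nc1ccc2cccc(NC(=O)Nc3ccc(Cl)c(C(F)(F)F)c3)c2c1` bears a methanesulfonamide on a related bicyclic ring; compound 3 `NS(=O)(=O)Cc1ccccc1NC(=O)Nc1ccc(Cl)c(C(F)(F)F)c1` carries a single benzene ring with a sulfamoylmethyl group. In an in vitro functional assay on cells for antagonist activity at transient receptor potential cation channel subfamily V member 1 (Homo sapiens), read by reporter gene assay and calcium flux (a lower number here means a stronger inhibitor, a higher number a weaker inhibitor), compound 1 gives 45 nM. For compound 2 this assay reports only the limit > 1000 nM, which is not a number. Compound 3 gives 460 nM in this assay, the highest of the two numbers, and its nearest neighbour is compound 1, whose value is lower by a gap well beyond the usual scatter of repeats.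

Compound 4 `NS(=O)(=O)c1ccccc1NC(=O)Nc1ccc(Cl)c(C(F)(F)F)c1` is the next step: sulfamoyl in place of sulfamoylmethyl on an aromatic carbon, so the sulfonamide sits directly on the aromatic carbon, ortho to a large group. Among the compounds with values here, no measured pair shows the effect of removing such a linking carbon here, so the estimate leans on compound 3 alone. Compound 4 is expected to give about 700 nM, within a range of 150 nM to 3000 nM. The step of a 1.5-fold higher number from compound 3 to compound 4 (0.18 log units; within the scatter) is thus estimated to be small, toward a weaker inhibitor, and may not exceed the scatter.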

Compound 4, half-maximal inhibitory concentration: > 1000 nM
Compound 4 gave a limit, no number; the forecaster's own chance of this, stated with the estimate: 25%; at least 1.4-fold (0.15 log units) between middle value and limit.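

Replacing sulfamoylmethyl with sulfamoyl on this aromatic carbon, ortho to a large group, removes only the linking carbon, yet in this assay it gives an at least 2.1-fold higher number from compound 3 to compound 4 (0.33 log units; beyond the scatter). This is the only pair shown that differs in one place, so it is the first direct sign that this position responds to such a small change, and the response is toward a weaker inhibitor. Compound 4 gives only a limit, > 1000 nM, so the step is a minimum and its full size stays unknown, because the assay stops at a ceiling: the limit of > 1000 nM in this assay, at which 2 of the 4 values shown sit.

What the compounds shown leave open is how a longer chain carrying the sulfonamide would behave at this position, and whether an amine or a carboxylic acid on the same carbon would give a stronger inhibitor than compound 3, with its 460 nM. Within the data shown here, also open is whether the hydroxy group of compound 1, which gives 45 nM, would keep that value if placed on the single benzene ring of compound 3.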